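The source may report more compounds than this note shows. Statements on the series, on what has been measured and on what is new or still open speak of the compounds shown alone.

Of the compounds shown here, two have been measured so far. In a functional assay on PC-3 cells (Homo sapiens) for antiproliferative activity, read by MTT assay, with a stated time of 72 h (on this read-out higher numbers stand for weaker inhibition and lower numbers for stronger inhibition), compound 1 (`CCOC(=O)c1csc2nc(CN3CCN(Cc4ccccc4)CC3)c(-c3ccc(OC)cc3)n12`) gives 29400 nM and compound 2 (`CCOC(=O)c1csc2nc(CN3CCN(C)CC3)c(-c3ccc(Br)cc3)n12`) gives 85000 nM as the higher of the two numbers, a gap beyond the usual scatter. Compound 3 (`CCOC(=O)c1csc2nc(CN3CCN(Cc4ccccc4)CC3)c(-c3ccc(Br)cc3)n12`) takes compound 2 and changes methyl to benzyl, which means phenyl in place of hydrogen on a saturated chain carbon bound to an amine nitrogen in a ring. Going by the values given here, no two measured compounds differ in one place only, so the size of this step has not been seen directly. Compound 1 also carries a benzyl and stands at 29400 nM in this assay as the only hint, which points towards a moderate move to a lower number. The expected change is a 2.8-fold lower number from compound 2 to compound 3 (0.45 log units; beyond the scatter) with real doubt about its size. For compound 3 the estimated value is 30000 nM with an expected range from 10000 nM to 80000 nM in this measurement.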

Compound 3, half-maximal inhibitory concentration: 56400 nM
Compound 3: middle estimate off by 1.9-fold (0.27 log units), on the low side; the range from low to high includes it.
By their numbers in this assay, from the lowest: compounds 1, 3 and 2 (each within the scatter of the next, the first and the last beyond it).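

In this assay, going by these compounds alone, the first direct reading of methyl to benzyl, with the bromo group kept in place, gives a 1.5-fold lower number from compound 2 to compound 3 (0.18 log units; within the scatter) and so shows that phenyl in place of hydrogen at this position makes no clear difference here. The bromo group can now be read against methoxy on an aromatic carbon as well, and this one-place change gives a 1.9-fold higher number from compound 1 to compound 3 (0.28 log units; within the scatter) and so also stays inside the usual scatter of the measurement. No measurement shown here explains either reading.

Still open, going by these compounds, is whether a different group on the amine nitrogen in the ring, such as a longer chain or cyclohexylmethyl, would move the number beyond the scatter. The same question holds for chloro, an amine or a carboxylic acid on the aromatic carbon that carries bromo or methoxy.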